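This account rests on a few compounds, and the source may have more. Where it says the series, first, only, none or still open, it means among the compounds named here.

In a functional assay on MCF7 cells (Homo sapiens) for antiproliferative activity, read by MTT assay, with a stated time of 72 h (a higher number here means a weaker inhibitor, a lower number a stronger inhibitor), compound 3 `O=C(N/N=C/c1ccco1)c1cccc(S(=O)(=O)N2CCOCC2)c1` gives > 100000 nM, which is a limit and not a number. Compound 1 `C/C(=N\NC(=O)c1cccc(S(=O)(=O)N2CCOCC2)c1)c1ccc(O)cc1` gives > 100000 nM, also a limit. Compound 2 `C/C(=N\NC(=O)c1cccc(S(=O)(=O)N2CCOCC2)c1)c1cc(F)ccc1O` reaches a true number, 6650 nM. Compound 4 `O=C(N/N=C/c1cc(Br)cc(Br)c1O)c1cccc(S(=O)(=O)N2CCOCC2)c1` differs from compound 3 by one change, 3,5-dibromo-2-hydroxyphenyl in place of furan-2-yl on a carbon with a double bond to nitrogen. Among the compounds with values here, the one measured step that bears on this is an at least 15-fold lower number from compound 1 to compound 2 (1.17 log units; beyond the scatter). The 3,5-dibromo-2-hydroxyphenyl group of compound 4 resembles the 5-fluoro-2-hydroxyphenyl group of compound 2, although the group that leaves is different. A large step toward a lower number is therefore expected, an at least 12-fold lower number from compound 3 to compound 4 (1.09 log units; beyond the scatter). For compound 4, the estimated value is 8000 nM, with an expected range of 2000 nM to 35000 nM.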

Compound 4, half-maximal inhibitory concentration: 16000 nM
Estimate against measurement, compound 4: 2.0-fold (0.30 log units) below; the range from low to high includes it.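

Replacing furan-2-yl with 3,5-dibromo-2-hydroxyphenyl on a carbon with a double bond to nitrogen gives an at least 6.2-fold lower number from compound 3 to compound 4 (0.79 log units; beyond the scatter). This shows that the gain seen with 5-fluoro-2-hydroxyphenyl in compound 2 is not unique to that group, as a second halogen-bearing 2-hydroxyphenyl group also gives a true number. The step's full size stays unknown because compound 3 sits at a limit: the limit of > 100000 nM in this assay, at which 2 of the 4 values shown sit.

The compounds shown leave open whether the hydroxyl, the bromine atoms or the six-membered ring accounts for the step. A plain phenyl or an unsubstituted 2-hydroxyphenyl group would separate these parts.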